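The source may hold more compounds than are shown below. What is called first, only, known or untested is meant among the compounds shown, and "the series" means these compounds.

Compound 2 `CC(C)n1nc(N2CC(CO)C2)c2cnc(Nc3ccnc(-c4cnn(S(=O)(=O)C5CC5)c4)n3)cc21` and compound 1 `CC(C)n1nc(N)c2cnc(Nc3ccnc(-c4cnn(S(=O)(=O)C5CC5)c4)n3)cc21` share one core and differ where an azetidine with a hydroxymethyl group replaces an amino group. In a physicochemical assay for solubility, in phosphate buffer, measured as kinetic solubility, with a stated time of 24 h, at pH 7.4, tested at 100 uM (on this read-out higher numbers stand for higher solubility and lower numbers for lower solubility), compound 1 gives 2000 nM, and compound 2 gives 3000 nM. Among the measured compounds shown here, the only measured step, a 1.5-fold higher number from compound 1 to compound 2 (0.18 log units; within the scatter), leaves compound 2 with the higher of the two numbers, though not by more than the scatter. Compound 3 `CC(C)n1nc(N2CC(C(C)(C)O)C2)c2cnc(Nc3ccnc(-c4cnn(S(=O)(=O)C5CC5)c4)n3)cc21` carries a further change, (1-hydroxy-1-methylethyl in place of hydroxymethyl on a saturated ring carbon). For the measured compounds named here, no measured step bears on this change, so compound 3 is expected to show a step of about a 1.2-fold lower number from compound 2 to compound 3 (0.08 log units; within the scatter) in this assay, not beyond the scatter, with an estimate of 2500 nM in the range 1000 nM to 7000 nM.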

Compound 3, solubility: < 1000 nM
Compound 3: only a limit was reported; the forecaster's own chance of this, stated with the estimate: 5%; middle value at least 2.5-fold (0.39 log units) away from the limit.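

In this assay the change from hydroxymethyl to 1-hydroxy-1-methylethyl on a saturated ring carbon gives an at least 3.0-fold lower number from compound 2 to compound 3 (0.47 log units; beyond the scatter) and is the only step shown that clears the scatter, so this position responds to a change in the group it carries. Measured against the amino group, the new side chain gives an at least 2.0-fold lower number from compound 1 to compound 3 (0.30 log units; that floor lies within the scatter) and so settles no order between those two compounds. Compound 3 has a limit and not a number: the limit of < 1000 nM in this assay, at which 1 of the 3 values shown sits.

The compounds shown leave open how far compound 3 lies under its limit. They also leave open how a primary amine or a carboxylic acid would read on this ring carbon.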